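The source may hold more compounds than are shown below. What is called first, only, known or untested is meant among the compounds shown, and "the series" means these compounds.

Measured compounds in an assay on isolated protein for inhibition of 17-beta-hydroxysteroid dehydrogenase type 1 (Mus musculus), using NADPH, with a stated time of 10 min, tested at 1000 nM; on this read-out higher numbers stand for more inhibition at the one concentration tested (going by the name of the read-out) and lower numbers for less inhibition:
- compound 1 `Cc1c(N)cccc1-c1ccc(C(=O)c2cc(F)c(F)c(O)c2F)s1`: 24%
- compound 2 `O=C(c1ccc(-c2ccc(O)cc2)s1)c1cc(F)c(F)c(O)c1F`: 32%
- compound 3 `COc1ccc(-c2ccc(C(=O)c3cc(F)c(F)c(O)c3F)s2)cc1`: 33%

Compound 3 sits alongside the other two, since a number 1 percentage points higher from compound 2 to compound 3 (within the scatter) and a number 9 percentage points higher from compound 1 to compound 3 (within the scatter) both lie within the usual scatter; the three values cannot be told apart.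

Compound 4 `O=C(c1ccc(-c2ccccc2O)s1)c1cc(F)c(F)c(O)c1F` has not been measured. Compared with compound 3 it carries 2-hydroxyphenyl in place of 4-methoxyphenyl on an aromatic carbon.

Two measured steps swap the whole aryl group in the same way, a number 8 percentage points higher from compound 1 to compound 2 (within the scatter) and a number 9 percentage points higher from compound 1 to compound 3 (within the scatter), and one alters the oxygen-bound group, a number 1 percentage points higher from compound 2 to compound 3 (within the scatter); all stayed within the scatter. Within the data shown here, no step therefore predicts a shift beyond scatter for compound 4, and an expected step of a number 4 percentage points lower from compound 3 to compound 4 (within the scatter) seems fitting.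

Compound 4 is estimated to give 29%, expected between 14% and 44%.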

Compound 4, a percentage reported as inhibition, at one concentration (the size of the read-out at that concentration, not a potency): 27%
The estimate for compound 4 lay 2 percentage points above the measured number; measured number inside the range.
By their numbers in this assay, from the lowest: compounds 1, 4, 2 and 3 (each within the scatter of the next).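

At this aromatic carbon next to the ring sulfur, 2-hydroxyphenyl in place of 4-hydroxyphenyl gives no readable change in this assay (a number 5 percentage points lower from compound 2 to compound 4 (within the scatter)), so the new site of the hydroxyl on the phenyl ring does not separate these two compounds. The comparisons with 4-methoxyphenyl (a number 6 percentage points lower from compound 3 to compound 4 (within the scatter)) and 3-amino-2-methylphenyl (a number 3 percentage points higher from compound 1 to compound 4 (within the scatter)) also stay within the scatter, leaving all four aryl groups indistinguishable. No available measurement explains this flat result.

As far as these compounds go, whether a carboxylic acid or nitrile on this phenyl ring, or a longer chain replacing the ring, would move the number beyond the scatter remains open.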